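The compounds below may be only part of what the source reports. "The series", "measured", "known", "first", "only" and "open" are said of these compounds alone.

Measured so far in an assay on HEK293 cells for displacement of a labelled ligand from Neuronal acetylcholine receptor; alpha4/beta2 (Rattus norvegicus), with a stated time of 4 h; a higher number here means a weaker inhibitor, a lower number a stronger inhibitor: compound 1 `CO[C@H]1CC=C2CCN(C)[C@H]2C1` gives 3400 nM; compound 2 `CCO[C@H]1CC=C2CCN(C)[C@H]2C1` gives 300000 nM.

Going by the values given here, compound 2 has the highest number of the two; the only neighbour is compound 1, with an 88-fold higher number from compound 1 to compound 2 (1.95 log units; beyond the scatter). Compound 3 `CN1CCC2=CC[C@H](OCc3ccccc3)C[C@@H]21` differs from compound 2 by phenyl in place of methyl on a saturated chain carbon bound to an oxygen on a saturated carbon. Among the compounds with values here, the single measured step bears on it only loosely: growth on that chain carbon gave a large rise in this assay, and the phenyl is a further enlargement, so a rise or no change beyond the scatter is expected, not a fall. Compound 3 is therefore estimated at 500000 nM (range 50000 nM to 3000000 nM), meaning an expected 1.7-fold higher number from compound 2 to compound 3 (0.22 log units; within the scatter).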

Compound 3, inhibition constant: 300000 nM
Estimate against measurement, compound 3: 1.7-fold (0.22 log units) above; low and high end bracket the measured number.
By their numbers in this assay, from the lowest: compound 1; then compounds 2 and 3 (each within the scatter of the next).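

In this assay, phenyl in place of methyl on a saturated chain carbon bound to an oxygen on a saturated carbon gives no change at the digits printed from compound 2 to compound 3 (within the scatter), so further enlargement at this place does not extend the earlier large step. Phenyl in place of hydrogen at the same place gives an 88-fold higher number from compound 1 to compound 3 (1.95 log units; beyond the scatter), which matches the step already reached with methyl. No measurement on hand bears on the reason for this.

On these data alone, it remains open whether any group here other than hydrogen keeps the number of compound 1 3400 nM. A hydroxyl, an amine or a carboxylic acid on this chain carbon would test that.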